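The compounds below may be only part of what the source reports. "The series", "measured", "known", "first", "only" and "open" are said of these compounds alone.

Working notes on the series.

Compound 1 `CCOC(=O)c1c(-c2cccc(OC(F)(F)F)c2)[nH]c2cc(OC)ccc2c1=O`, compound 2 `CCOC(=O)c1c(-c2cccc(C(F)(F)F)c2)[nH]c2cc(OC)ccc2c1=O` and compound 3 `CCOC(=O)c1c(-c2cccc(OC)c2)[nH]c2cc(OC(F)(F)F)ccc2c1=O` have been measured in an ADME assay on Raji cells (Homo sapiens) for cytotoxicity, read by luminescence, with a stated time of 72 h; on this read-out lower numbers stand for an effect already at smaller amounts and higher numbers for an effect only at larger amounts of compound. Compound 1 gives > 21500 nM, which is a limit of the assay and not a number. Compound 2 gives > 21500 nM, likewise a limit. Compound 3 gives > 21500 nM, again a limit. The step from compound 1 to compound 2 is trifluoromethyl in place of trifluoromethoxy on an aromatic carbon, and in this assay it is a step that the two limits leave unreadable from compound 1 to compound 2; this rests on (the limit of > 21500 nM in this assay, at which 3 of the 3 values shown sit). Compound 1 and compound 3 are built from the same atoms joined differently, and the difference between the two cores is not broken down here.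

Compound 4 `CCOC(=O)c1c(-c2cccc(OC)c2)[nH]c2cc(C(F)(F)F)ccc2c1=O` has not yet been measured. It differs from compound 3 by trifluoromethyl in place of trifluoromethoxy on an aromatic carbon. This is the same kind of change as that from compound 1 to compound 2, though the place is not the same: in the earlier pair the group sits on a six-membered aromatic ring of carbon only, meta to a large group, whereas here it sits on a six-membered aromatic ring of carbon only that is part of a fused or bridged system of two rings, meta to a fused ring and para to a fused ring.

Going by the values given here, since every value so far sits at the limit (the limit of > 21500 nM in this assay, at which 3 of the 3 values shown sit), and the earlier step that the two limits leave unreadable from compound 1 to compound 2 could not be read, the step from compound 3 to compound 4 in this assay is expected to be a step that the limit leaves unreadable from compound 3 to compound 4, with a limit again the most likely outcome. For compound 4 the expected value in this assay is 30000 nM, estimated to fall between 15000 nM and 100000 nM.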

Compound 4, half-maximal effective concentration: > 21500 nM
Compound 4: only a limit was reported; the forecaster's own chance of this, stated with the estimate: 85%; the middle value does not contradict the limit.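

In this assay compound 4 gives > 21500 nM, which is a limit of the assay and not a number. Compound 3 also stands at a limit, so no size can be read for the change from trifluoromethoxy to trifluoromethyl between compound 3 and compound 4: the limit of > 21500 nM in this assay, at which 4 of the 4 values shown sit.

The compounds shown leave open at what concentration, if any, these four compounds would show an effect in this assay, and so whether this change matters there at all.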